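From Ethynyl to Thiophen-3-yl in a Growth Assay

A few compounds are considered here, and "the series" means these few. Any claim that something is new, unique, unknown or untested is made for them only; others in the source may bear on it.

In a functional assay on U-373MG ATCC cells for inhibition, with U373 MG (Homo sapiens) as the target, read by MTT assay, with a stated time of 7 days (on this read-out lower numbers stand for stronger inhibition of growth and higher numbers for weaker inhibition of growth), compound 1 `Cc1cc(Cn2nnc3c(C(N)=O)ncn3c2=O)on1` gives > 50000 nM, which is a limit and not a number. For the measured compounds named here, compound 2 `C#CC/N=N/Nc1[nH]cnc1C(N)=O` stands at 32000 nM, the only true number available in this assay. Compound 3 `NC(=O)c1nc[nH]c1N/N=N/Cc1ccsc1` has thiophen-3-yl in place of ethynyl on a saturated chain carbon bound to a double-bonded nitrogen. Going by the values given here, no measured step shows what such a change does, so only a small shift towards stronger inhibition, not beyond the scatter, is expected. The estimated step is a 1.1-fold lower number from compound 2 to compound 3 (0.06 log units; within the scatter). For compound 3, the estimated value is 28000 nM, with an expected range of 11000 nM to 50000 nM.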

Compound 3, concentration for 50% growth inhibition: > 50000 nM
Compound 3 was reported as a limit (the forecaster's own chance of this, stated with the estimate: 20%); middle value at least 1.7-fold (0.25 log units) from the limit.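

For the compounds shown here, the first measured step at this place, thiophen-3-yl in place of ethynyl on a saturated chain carbon bound to a double-bonded nitrogen, is an at least 1.5-fold higher number from compound 2 to compound 3 (0.19 log units; that floor lies within the scatter) in this assay. The ring brings no measurable gain in inhibition of growth over ethynyl. The step has only a floor because compound 3 is reported as a limit and not a number: the limit of > 50000 nM in this assay, at which 2 of the 3 values shown sit.

As far as these compounds go, how far the step truly runs stays open. So does what a phenyl ring, an amine or a longer chain would give at this place.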